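Phenyl for Methyl on the Shared Core

A few compounds are considered here, and "the series" means these few. Any claim that something is new, unique, unknown or untested is made for them only; others in the source may bear on it.

Measured compounds:
compound 1 `Cc1cc2[nH]nc(N)c2c(=O)[nH]1`: -1%
compound 2 `Nc1n[nH]c2cc(CC3CCNCC3)[nH]c(=O)c12`: -6%
compound 3 `Cc1cc2c(c(N)nn2C)c(=O)[nH]1`: 5%

All three were tested in an assay on isolated protein for inhibition of serine/threonine-protein kinase D2 (Homo sapiens), read by mobility shift assay, tested at 30 uM; a higher number here means more inhibition at the concentration tested (going by the name of the read-out), a lower number less inhibition. The number for compound 3 is the highest of the three, but compound 1 sits within the scatter of it; only compound 2 lies beyond. Compound 4 `Cn1nc(N)c2c(=O)[nH]c(-c3ccccc3)cc21` is not yet measured. It differs from compound 3 by phenyl in place of methyl on an aromatic carbon. Among the compounds with values here, two measured steps bear on it, both weakly. The step of a number 5 percentage points lower from compound 1 to compound 2 (within the scatter) concerns a saturated chain carbon and stays within the scatter. The step of a number 6 percentage points higher from compound 1 to compound 3 (within the scatter) concerns an aromatic nitrogen and also stays within the scatter. Neither step touches the aromatic carbon that changes here, and neither introduces a ring. Since every recorded change in this assay has left the read-out flat, the step of no change at the digits printed from compound 3 to compound 4 (within the scatter) is expected to be small and not beyond the scatter. Compound 4 is therefore estimated to give 5%, with a range of -10% to 20%.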

Compound 4, a percentage reported as inhibition, at one concentration (the size of the read-out at that concentration, not a potency): 14%
Beside the measured number, compound 4's estimate is 9 percentage points below it; measured number inside the range.
By their numbers in this assay, from the lowest: compounds 2, 1, 3 and 4 (each within the scatter of the next, the first and the last beyond it).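

In this assay, phenyl in place of methyl on the aromatic carbon next to the ring nitrogen gives a number 9 percentage points higher from compound 3 to compound 4 (within the scatter). This is the only step shown at an aromatic carbon and the only one that brings in a six-membered aromatic ring of carbon only, and with 6 heavy atoms entering where 1 leaves, the read-out at this position still stays within the scatter. Nothing available explains this step.

On these data alone, whether an amine or a carboxylic acid carried on the phenyl, or a longer chain on this aromatic carbon, would move the number beyond the scatter remains open. Also open, as far as these compounds go, is whether phenyl here would read the same with hydrogen instead of methyl on the aromatic nitrogen.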